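Swapping the amine on a terpenoid core for a sulfur-bearing group

The source may hold more compounds than are shown below. What is called first, only, known or untested is meant among the compounds shown, and "the series" means these compounds.

For the measured compounds named here, compound 2 `CC(C)=CCC[C@]1(C)/C=C/[C@@H](OC(=O)C=C(C)C)[C@](C)(O)/C=C/C(=O)/C(CN(C(C)C)C(C)C)=C\C1` has the lower of the two numbers measured so far: in a functional assay on SMMC-7721 cells (Homo sapiens) for antiproliferative activity, read by MTT assay, with a stated time of 48 h (on this read-out higher numbers stand for weaker inhibition and lower numbers for stronger inhibition), compound 2 gives 340 nM, while compound 1 `C=C1/C=C/C(=O)/C(CO)=C\C[C@](C)(CCC=C(C)C)/C=C/[C@H]1OC(=O)C=C(C)C` gives 4300 nM, a gap well beyond the scatter. Compound 3 `CSC(=S)OC/C1=C/C[C@](C)(CCC=C(C)C)/C=C/[C@@H](OC(=O)C=C(C)C)[C@](C)(O)/C=C/C1=O` differs from compound 2 in one place: a group of 5 heavy atoms (2 carbon, 1 oxygen, 2 sulfur; no ring) in place of a group of 7 heavy atoms (6 carbon, 1 nitrogen; no ring), on a saturated chain carbon bound to a double-bonded ring carbon. Going by the values given here, no step of this kind has been measured here, so the direction rests on expectation alone. Compound 3 is expected to be somewhat weaker, with a step of a 2.6-fold higher number from compound 2 to compound 3 (0.42 log units; beyond the scatter). Compound 3 is estimated at 900 nM, within a range from 250 nM to 4000 nM.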

Compound 3, half-maximal inhibitory concentration: 720 nM
Compound 3: middle estimate off by 1.3-fold (0.10 log units), on the high side, and the stated range covers the measured number.
By their numbers in this assay, from the lowest: compound 2; then compound 3; then compound 1.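

The amine is not required at this place, on a saturated chain carbon bound to a double-bonded ring carbon. In this assay, replacing diisopropylamino with a nitrogen-free, sulfur-bearing group gives only a modest loss, a 2.1-fold higher number from compound 2 to compound 3 (0.33 log units; beyond the scatter), though this still lies beyond the usual scatter. No measurement here explains the size of this step.

Going by these compounds, it remains open whether the amine's particular shape matters, as a smaller dimethylamino group or a ring amine such as morpholine could show. A simple methylthio group could likewise show how much of the sulfur-bearing group is needed.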